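A few compounds are considered here, and "the series" means these few. Any claim that something is new, unique, unknown or untested is made for them only; others in the source may bear on it.

Of the compounds shown here, three with a shared core have been tested in an assay on isolated protein for inhibition of thyroid hormone receptor beta (Homo sapiens), read by fluorescence polarization; a higher number here means a weaker inhibitor, a lower number a stronger inhibitor. Compound 1 is `CC(C)N(C(=O)CCNC(=O)c1ccc(S(C)(=O)=O)c([N+](=O)[O-])c1)C(C)C`. In this assay compound 1 gives > 60000 nM, which is a limit of the assay rather than a number. Compound 3 is `CS(=O)(=O)c1ccc(C(=O)NCCC(=O)N2CCc3ccccc3C2)cc1[N+](=O)[O-]`. In this assay compound 3 gives > 60000 nM, again a limit. The two differ in one place: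

1,2,3,4-tetrahydroisoquinolin-2-yl in place of diisopropylamino on a carbonyl carbon

The step that the two limits leave unreadable from compound 1 to compound 3 cannot be read, since both values are limits. Compound 2 is `CC(C)N(C(=O)C1CCN(C(=O)c2ccc(S(C)(=O)=O)c([N+](=O)[O-])c2)CC1)C(C)C`. In this assay compound 2 gives > 60000 nM, also a limit. The difference between the cores of compound 1 and compound 2 is not broken down here.

Compound 4, `CS(=O)(=O)c1ccc(C(=O)N2CCC(C(=O)N3CCc4ccccc4C3)CC2)cc1[N+](=O)[O-]`, has not yet been measured. It differs from compound 2 in one place:

1,2,3,4-tetrahydroisoquinolin-2-yl in place of diisopropylamino on a carbonyl carbon

This is the same kind of change as that from compound 1 to compound 3, but the surroundings differ: the carbonyl carbon sits on a saturated chain carbon in compound 1 and on a saturated ring carbon in compound 2.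

Going by the values given here, the only evidence is the limit of > 60000 nM in this assay, at which 3 of the 3 values shown sit. With every measured value sitting at the limit, the step from compound 2 to compound 4 is expected to be a step that the limit leaves unreadable from compound 2 to compound 4. Compound 4 is therefore estimated at 90000 nM, most likely again reported only as a limit, with a plausible range from 30000 nM to 400000 nM.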

Compound 4, half-maximal inhibitory concentration: > 60000 nM
Compound 4: a limit, no number; the forecaster's own chance of this, stated with the estimate: 85%; the middle value is on the limit's open side.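

Compound 4 and compound 2 are both reported only as limits of the assay rather than numbers, so the step between them cannot be read, and neither can the same change from compound 1 to compound 3. What stands on record is this: the limit of > 60000 nM in this assay, at which 4 of the 4 values shown sit. The compounds shown leave open whether swapping diisopropylamino for 1,2,3,4-tetrahydroisoquinolin-2-yl changes inhibition at all in this assay.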